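Fluoro in Place of Hydrogen on the Core of Compound 1

A few compounds are considered here, and "the series" means these few. Any claim that something is new, unique, unknown or untested is made for them only; others in the source may bear on it.

Compound 1, `O=C(NC1(C(=O)O)CCCCC1)c1cccc2cc(-c3ccc(Cl)cc3)oc12`, is the starting point; in an assay on isolated protein for inhibition of endoplasmic reticulum aminopeptidase 1 (Homo sapiens), with stated times of 15 min and 20 min (on this read-out lower numbers stand for stronger inhibition and higher numbers for weaker inhibition), compound 1 gives 120 nM. Compound 2, `O=C(NC1(C(=O)O)CCCCC1)c1cccc2c(Br)c(-c3ccc(Cl)cc3)oc12`, carries bromo in place of hydrogen on an aromatic carbon and gives 151 nM, a step of a 1.3-fold higher number from compound 1 to compound 2 (0.10 log units; within the scatter). Compound 1 thus holds the lowest of the two numbers, with compound 2 within the scatter of it. Compound 3, `O=C(NC1(C(=O)O)CCCCC1)c1cc(F)cc2cc(-c3ccc(Cl)cc3)oc12`, differs from compound 1 by fluoro in place of hydrogen on an aromatic carbon. Within the data shown here, the only step at hand, from compound 1 to compound 2, stayed within the scatter, so no step beyond the scatter is expected here either. For compound 3 an estimate of 130 nM (60 nM to 280 nM) is expected, corresponding to a 1.1-fold higher number from compound 1 to compound 3 (0.03 log units; within the scatter).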

Compound 3, half-maximal inhibitory concentration: 34 nM
Compound 3: middle estimate off by 3.8-fold (0.58 log units), on the high side; measured number outside the range, below it.
By their numbers in this assay, from the lowest: compound 3; then compounds 1 and 2 (each within the scatter of the next).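

In this assay, fluoro in place of hydrogen on an aromatic carbon gives a 3.5-fold lower number from compound 1 to compound 3 (0.55 log units; beyond the scatter) and is the only step shown that lies beyond the scatter, while bromo on compound 2 gave a 1.3-fold higher number from compound 1 to compound 2 (0.10 log units; within the scatter). A single fluorine atom at this position of the core of compound 1 is thus enough to shift the number. Nothing at hand accounts for this step.

Going by these compounds, whether chloro, methoxy or an amine at this position would go further remains open. So does whether fluoro on the other aromatic carbons of the core would give a similar step.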